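A few compounds are considered here, and "the series" means these few. Any claim that something is new, unique, unknown or untested is made for them only; others in the source may bear on it.

Compound 2 `O=C(Nc1cccc(-c2nc3ccccc3s2)c1)c1cnccc1Cl` carries a 4-chloropyridin-3-yl on its carbonyl carbon. In an ADME assay on HepG2 cells (Homo sapiens) for inhibition, with a stated time of 72 h (a higher number here means that more compound is needed for the effect, a lower number that less compound is needed), compound 2 gives > 25000 nM, which is a limit of the assay and not a number. For the measured compounds named here, its only measured neighbour is compound 1 `O=C(O)/C=C/C(=O)Nc1cccc(-c2nc3ccccc3s2)c1`. In this assay compound 1 gives > 25000 nM, again a limit rather than a number. The step that the two limits leave unreadable from compound 1 to compound 2 is therefore unreadable, and the limit of > 25000 nM in this assay, at which 2 of the 2 values shown sit, is the whole of the evidence available. Compound 3 `O=C(Nc1cccc(-c2nc3ccccc3s2)c1)c1ccc(Cl)nc1Cl` differs from compound 2 by 2,6-dichloropyridin-3-yl in place of 4-chloropyridin-3-yl on a carbonyl carbon. Going by the values given here, no measured step bears on this particular change, and both values shown are limits, so nothing points towards a reading inside the working range of this assay. The expected step is a step that the limit leaves unreadable from compound 2 to compound 3, nothing beyond the scatter. Compound 3 is estimated at 30000 nM, within 8000 nM to 100000 nM, and most likely reported once more as a limit.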

Compound 3, half-maximal effective concentration: > 25000 nM
Compound 3: no number, only a limit; the forecaster's own chance of this, stated with the estimate: 80%; the middle value is on the limit's open side.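

No step can be read among compound 1, compound 2 and compound 3, because all three stop at the same limit: the limit of > 25000 nM in this assay, at which 3 of the 3 values shown sit. From the compounds shown here alone, whether any group on the carbonyl carbon of the shared core gives a number in this assay rather than a limit stays open.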